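The source may hold more compounds than are shown below. What is called first, only, known or untested is meant among the compounds shown, and "the series" means these compounds.

Measured in a functional assay on ECa-109 cells for antiproliferative activity against ECa-109 cell line (Homo sapiens), read by MTT assay, with a stated time of 72 h; a lower number here means a stronger inhibitor, a higher number a weaker inhibitor:
- compound 1 `O=C(N/N=C/c1ccco1)c1cccc(S(=O)(=O)N2CCOCC2)c1`: > 100000 nM, a limit of the assay and not a number
- compound 2 `O=C(N/N=C/c1ccccc1O)c1cccc(S(=O)(=O)N2CCOCC2)c1`: 14400 nM
- compound 3 `COc1ccc(/C=N/NC(=O)c2cccc(S(=O)(=O)N3CCOCC3)c2)c(O)c1`: 2790 nM

At 2790 nM, compound 3 is the strongest inhibitor of the three and has the lower of the two actual numbers. The neighbouring step is a 5.2-fold lower number from compound 2 to compound 3 (0.71 log units; beyond the scatter).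

Compound 4 `O=C(N/N=C/c1cc(Cl)ccc1O)c1cccc(S(=O)(=O)N2CCOCC2)c1` has not yet been measured. It differs from compound 3 by 5-chloro-2-hydroxyphenyl in place of 2-hydroxy-4-methoxyphenyl on a carbon with a double bond to nitrogen.

Among the compounds with values here, three measured steps bear on this change. Putting 2-hydroxyphenyl in place of furan-2-yl gave an at least 6.9-fold lower number from compound 1 to compound 2 (0.84 log units; beyond the scatter), and 2-hydroxy-4-methoxyphenyl gave an at least 35-fold lower number from compound 1 to compound 3 (1.55 log units; beyond the scatter). Compound 4 keeps the 2-hydroxyphenyl part of these changes, so a value far from the limit of compound 1 seems likely. It loses the methoxy, however, whose addition gave a 5.2-fold lower number from compound 2 to compound 3 (0.71 log units; beyond the scatter). Within the data shown here, no measured step shows what chloro does. Compound 4 is therefore expected to land between compound 2 and compound 3, with a modest move towards a higher number in this assay.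

The expected step is a 2.0-fold higher number from compound 3 to compound 4 (0.29 log units; within the scatter). For compound 4 the estimated value is 5500 nM, with an expected range of 1500 nM to 20000 nM.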

Compound 4, half-maximal inhibitory concentration: 2840 nM
Compound 4: middle estimate off by 1.9-fold (0.29 log units), on the high side; the range from low to high includes it.
By their numbers in this assay, from the lowest: compounds 3 and 4 (each within the scatter of the next); then compound 2. At a limit, above all of these: compound 1.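

In this assay, within the data shown here, chloro in place of hydrogen on the aromatic ring gives a 5.1-fold lower number from compound 2 to compound 4 (0.71 log units; beyond the scatter), which is the first measured sign of what chloro does. Changing the whole group from 2-hydroxy-4-methoxyphenyl to 5-chloro-2-hydroxyphenyl gives a 1.0-fold higher number from compound 3 to compound 4 (0.01 log units; within the scatter), so the two groups cannot be told apart here, and the chloro step is about the same size as the methoxy step, a 5.2-fold lower number from compound 2 to compound 3 (0.71 log units; beyond the scatter). Compound 1 stands at a limit of the assay and not at a number, so 5-chloro-2-hydroxyphenyl in place of furan-2-yl can be stated only as a bound, an at least 35-fold lower number from compound 1 to compound 4 (1.54 log units; beyond the scatter), and the true size of the step stays unknown: the limit of > 100000 nM in this assay, at which 1 of the 4 values shown sits.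

The compounds shown leave open whether chloro and methoxy together on the 2-hydroxyphenyl ring would add up, and whether fluoro, bromo or methyl in place of chloro would give a similar step. Also open, as far as these compounds go, are whether the hydroxy group is needed at all and what an amine or a carboxylic acid on the same ring would do.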